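Swapping Propoxy for Methyl: Expected Cytotoxicity of Compound 4

A few compounds are considered here, and "the series" means these few. Any claim that something is new, unique, unknown or untested is made for them only; others in the source may bear on it.

Compound 1, `COC(=O)c1cc(-c2cccc(NC(=O)c3ccc(/C=C/C(=O)c4cccc(F)c4)cc3)c2)on1`, gives > 40 ug/mL in an ADME assay on Vero cells (Chlorocebus sabaeus) for cytotoxicity, read by MTT assay, with a stated time of 72 h (on this read-out lower numbers stand for higher toxicity in this test and higher numbers for lower toxicity in this test), which is a limit of the assay and not a number.
Compound 2, `COC(=O)c1cc(-c2cccc(NC(=O)c3ccc(/C=C/C(=O)c4cc(OC)c(OC)c(OC)c4)cc3)c2)on1`, gives > 50 ug/mL in this assay, again a limit.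
Compound 3, `CCCOc1ccc(C(=O)/C=C/c2ccc(C(=O)Nc3cccc(-c4cc(C(=O)OC)no4)c3)cc2)cc1`, gives > 40 ug/mL in this assay, also a limit.

Compound 3 therefore stands at a limit of this assay, and the two further values shown are limits too, as the limit of > 40 ug/mL in this assay, at which 2 of the 3 values shown sit, and the limit of > 50 ug/mL in this assay, at which 1 of the 3 values shown sits, record. Going by the values given here, none of the measured steps carries a readable size: a step that the two limits leave unreadable from compound 1 to compound 3, a step that the two limits leave unreadable from compound 2 to compound 3 and a step that the two limits leave unreadable from compound 1 to compound 2 all sit between limits.

Compound 4, `COC(=O)c1cc(-c2cccc(NC(=O)c3ccc(/C=C/C(=O)c4ccc(C)cc4)cc3)c2)on1`, differs from compound 3 in one place: methyl in place of propoxy on an aromatic carbon. Since every step among the three measured compounds is unreadable, no direction and no size can be taken from them for this change, and the expected step that the limit leaves unreadable from compound 3 to compound 4 is one not beyond the scatter, most likely again a limit. Compound 4 is accordingly estimated at 50 ug/mL, with a range from 30 ug/mL to 100 ug/mL.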

Compound 4, half-maximal cytotoxic concentration: > 80 ug/mL
Compound 4: no number, only a limit (the forecaster's own chance of this, stated with the estimate: 80%); at least 1.6-fold (0.20 log units) between middle value and limit.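

Compound 4, like compound 1, compound 2 and compound 3, gives only a limit in this assay, so none of the steps to compound 4 can be read. On these data alone, whether these four compounds truly differ in toxicity in this test, and by how much, stays open.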